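From (pentan-3-yl)oxy to sec-butoxy: compound 2 to compound 3

A few compounds are considered here, and "the series" means these few. Any claim that something is new, unique, unknown or untested is made for them only; others in the source may bear on it.

Compound 2 `CCC(CC)OC(=O)C1=C(C)NC(=O)NC1c1cccs1` stands highest of the two numbers measured in an assay on membranes from HEK293 cells for displacement of a labelled ligand from adenosine receptor A2b (Homo sapiens), read by scintillation counting, with a stated time of 30 min, tested at 1 uM (on this read-out higher numbers stand for more inhibition at the one concentration tested (going by the name of the read-out) and lower numbers for less inhibition), where compound 2 gives 6%. Its nearest neighbour is compound 1 `CCSC(=O)C1=C(C)NC(=O)NC1c1cccs1`, which in this assay gives 1%; the step of a number 5 percentage points higher from compound 1 to compound 2 (within the scatter) lies within the scatter. Compound 3 `CCC(C)OC(=O)C1=C(C)NC(=O)NC1c1cccs1` differs from compound 2 by hydrogen in place of methyl on a saturated chain carbon, two bonds along the chain from an oxygen next to a carbonyl group. Going by the values given here, no measured step alters this part of the molecule in the same way; the one step recorded, from compound 1 to compound 2, swapped the whole group on the carbonyl carbon and left the number essentially unchanged, and both measured values sit near the bottom of the scale. Compound 3 is therefore expected to stay low, with a step of a number 2 percentage points lower from compound 2 to compound 3 (within the scatter) that amounts to nothing beyond the scatter. The estimate for compound 3 in this assay is 4%, with a range from 0% to 15%.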

Compound 3, a percentage reported as inhibition, at one concentration (the size of the read-out at that concentration, not a potency): 7%
Estimate against measurement, compound 3: 3 percentage points below; measured number inside the range.
By their numbers in this assay, from the lowest: compounds 1, 2 and 3 (each within the scatter of the next).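

In this assay, going by these compounds alone, the change from (pentan-3-yl)oxy to sec-butoxy gives a number 1 percentage points higher from compound 2 to compound 3 (within the scatter) and is the first look at this position, showing that hydrogen in place of methyl on this saturated chain carbon leaves the number unchanged within the scatter. A second exchange on the carbonyl carbon, sec-butoxy in place of ethylsulfanyl, gives a number 6 percentage points higher from compound 1 to compound 3 (within the scatter) and so also stays within the scatter, while all three compounds remain near the bottom of the scale. Nothing available accounts for this flatness.

As far as these compounds go, it remains open whether a group of another kind on the carbonyl carbon, such as an amine or a carboxylic acid, would move the number beyond the scatter. From the compounds shown here alone, the effect of a longer chain on the oxygen also remains open, as does whether this position matters in a compound with a higher number.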